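This account rests on a few compounds, and the source may have more. Where it says the series, first, only, none or still open, it means among the compounds named here.

Compound 1 `O=c1cc(Cc2c(F)cccc2F)nc(Sc2ccccc2)[nH]1`: > 76000 nM
Compound 2 `Cc1ccc(CSc2nc(Cc3c(F)cccc3F)c(C)c(=O)[nH]2)c(C)c1`: > 65000 nM
Compound 3 `CC(C)Sc1nc(Cc2c(F)cccc2F)cc(=O)[nH]1`: not yet measured

In an ADME assay on MT4 cells (Homo sapiens) for cytotoxicity, read by MTT assay (a lower number here means that less compound is tolerated, a higher number that more compound is tolerated), compound 1 gives > 76000 nM, which is a limit of the assay and not a number. Compound 2 gives > 65000 nM, likewise a limit, so neither compound has a numerical value to place it by. Compound 3 carries isopropyl in place of phenyl on a sulfur. Within the data shown here, no measured pair shows the effect of such a change, and no shift beyond the usual scatter is expected, in either direction. The estimated step that the limit leaves unreadable from compound 1 to compound 3 is therefore expected to be small. For compound 3 the expected value in this assay is 84000 nM, with an estimated range of 40000 nM to 170000 nM.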

Compound 3, half-maximal cytotoxic concentration: > 84000 nM
Compound 3 was reported as a limit (the forecaster's own chance of this, stated with the estimate: 75%); the middle value sits exactly at the limit.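

Compound 1 and compound 3 are both reported only as limits in this assay, and the step between them, isopropyl in place of phenyl on a sulfur, cannot be read. The compounds shown leave open at what concentration any of them becomes cytotoxic, and whether that exchange on the sulfur makes any difference.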